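Replacing the dichlorophenyl of compound 1 with a fluorophenyl

This account rests on a few compounds, and the source may have more. Where it says the series, first, only, none or still open, it means among the compounds named here.

Compound 1 `Nc1scc(CN2CCN(c3cc(Cl)cc(Cl)c3)CC2)c1C(=O)c1ccc(Cl)cc1` is one of three thiophene-based compounds measured in a functional assay on CHO cells with adenosine receptor A1 (Homo sapiens) as the target, read by cAMP accumulation and immunoassay, with a stated time of 6 min, tested at 1 uM; a lower number here means a stronger effect, a higher number a weaker effect of the compound at the concentration tested. In this assay compound 1 gives -69%, the second highest of the three numbers. Compound 2 `Nc1scc(CN2CCN(c3cccc(C(F)(F)F)c3)CC2)c1C(=O)c1ccc(Cl)cc1` gives -72%, and compound 3 `Nc1scc(CN2CCN(c3ccc(OC(F)(F)F)cc3)CC2)c1C(=O)c1ccc(Cl)cc1` gives -51%. The step of a number 3 percentage points lower from compound 1 to compound 2 (within the scatter) lies within the scatter, whereas a number 18 percentage points higher from compound 1 to compound 3 (beyond the scatter) and a number 21 percentage points higher from compound 2 to compound 3 (beyond the scatter) are modest rises. Compound 4 `Nc1scc(CN2CCN(c3cccc(F)c3)CC2)c1C(=O)c1ccc(Cl)cc1` differs from compound 1 in one place: 3-fluorophenyl in place of 3,5-dichlorophenyl on an amine nitrogen in a ring. For the measured compounds named here, both measured steps touch the same ring nitrogen, and the closest precedent is the small step from compound 1 to compound 2. Compound 4 is therefore expected to sit near compound 1, with an estimated step of a number 7 percentage points higher from compound 1 to compound 4 (within the scatter), giving an estimate of -62% within -78% to -44%.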

Compound 4, a percentage reported as activity, at one concentration (the size of the read-out at that concentration, not a potency): -86%
Beside the measured number, compound 4's estimate is 24 percentage points above it, and the stated range ends above it.
By their numbers in this assay, from the lowest: compound 4; then compounds 2 and 1 (each within the scatter of the next); then compound 3.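

In this assay, for the compounds shown here, the earlier compounds showed changes on this ring nitrogen only holding the number or raising it, whereas 3-fluorophenyl takes it lower: a number 17 percentage points lower from compound 1 to compound 4 (beyond the scatter) and a number 35 percentage points lower from compound 3 to compound 4 (beyond the scatter). With a number 14 percentage points lower from compound 2 to compound 4 (beyond the scatter), fluoro in place of trifluoromethyl on one aromatic carbon is enough to move the number beyond the scatter, and compound 4 gives the strongest effect of the four at the concentration tested. No measurement shown here explains this gain.

Going by these compounds, it remains open how a nitrile or a methoxy group in place of the fluoro would read. A single concentration also leaves the potency of compound 4 unknown.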